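The source may hold more compounds than are shown below. What is called first, only, known or untested is meant among the compounds shown, and "the series" means these compounds.

Measured so far:
compound 1 `Cn1cc(C2=C(c3nn(CCn4ccnc4)c4ncccc34)C(=O)NC2=O)c2ccccc21` — > 100000 nM
compound 2 `Cn1cc(C2=C(c3nn(CCCn4ccnc4)c4ncccc34)C(=O)N(c3ccccc3)C2=O)c2ccccc21` — 34800 nM
compound 3 `COc1ccc(N2C(=O)C(c3cn(C)c4ccccc34)=C(c3nn(CCCN4CCCCC4)c4ncccc34)C2=O)cc1` — 1740 nM

In a functional assay on SMMC-7721 cells (Homo sapiens) for antiproliferative activity, read by MTT assay, with a stated time of 48 h (on this read-out higher numbers stand for weaker inhibition and lower numbers for stronger inhibition), compound 1 reaches only a limit, > 100000 nM, so its place among the measured numbers is not a number at all but (the limit of > 100000 nM in this assay, at which 1 of the 3 values shown sits). Compound 2 gives 34800 nM and compound 3 gives 1740 nM; neither is joined to compound 1 by a single change, so nothing more is drawn from that pair here. Compound 4 `Cn1cc(C2=C(c3nn(CCCn4cncn4)c4ncccc34)C(=O)NC2=O)c2ccccc21` differs from compound 1 by one change, ((1H-1,2,4-triazol-1-yl)methyl in place of 1H-imidazol-1-yl on a saturated chain carbon, two bonds along the chain from an aromatic nitrogen). Going by the values given here, no measured step of this kind exists, so the expected shift in this assay is none beyond the usual scatter, and compound 4 is estimated to keep the weak inhibition of compound 1, the expected step being a number no higher from compound 1 to compound 4 (the limit leaves the size open). Compound 4 is therefore expected near 100000 nM, between 30000 nM and 300000 nM.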

Compound 4, half-maximal inhibitory concentration: > 100000 nM
Compound 4 gave a limit, no number (the forecaster's own chance of this, stated with the estimate: 50%); the middle value sits exactly at the limit.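

Compound 1 and compound 4 each give only a limit, and no step can be read between them. The compounds shown leave open whether (1H-1,2,4-triazol-1-yl)methyl in place of 1H-imidazol-1-yl changes inhibition at all.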